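The source may hold more compounds than are shown below. What is called first, only, known or untested is meant among the compounds shown, and "the series" means these compounds.

Measured compounds:
- compound 1 `NC1=NC2(CCSCC2)N(OCCCOc2cccc(Cl)c2)C(N)=N1`: 60 nM
- compound 2 `NC1=NC2(CCOCC2)N(OCCCOc2ccc(Cl)cc2)C(N)=N1`: 360 nM
- compound 3 `NC1=NC2(CCOCC2)N(OCCCOc2ccccc2Cl)C(N)=N1`: 2700 nM

These three were tested in a functional assay on A549 cells (Homo sapiens) for antiproliferative activity, read by MTT assay, with a stated time of 72 h; a lower number here means a stronger inhibitor, a higher number a weaker inhibitor. Compound 1 stands lowest at 60 nM, and its gaps to both of the others lie beyond the scatter. Compound 2 is its nearest neighbour and compound 3 its furthest.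

The next compound, compound 4 `NC1=NC2(CCSCC2)N(OCCCOc2cc(Cl)c(Cl)cc2Cl)C(N)=N1`, keeps the core of compound 1 and changes only the aryl group: 2,4,5-trichlorophenyl in place of 3-chlorophenyl on an oxygen on a saturated carbon. That is, 2,4,5-trichlorophenyl takes the place of 3-chlorophenyl on an oxygen on a saturated carbon.

Going by the values given here, only one measured step bears on this change, and it comes from a different core: a 7.5-fold higher number from compound 2 to compound 3 (0.88 log units; beyond the scatter). There, 2-chlorophenyl replaced 4-chlorophenyl. The entering 2,4,5-trichlorophenyl carries the chlorine numbering of both groups in that pair, so the step gives no clear direction. Among the compounds with values here, no measured compound shows the effect of adding chlorines to one ring. A small rise in this assay is therefore expected, perhaps none beyond the scatter, with wide uncertainty in either direction.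

The expected change is a 2.0-fold higher number from compound 1 to compound 4 (0.30 log units; within the scatter). For compound 4 the estimated value is 120 nM, with an expected range from 25 nM to 600 nM.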

Compound 4, half-maximal inhibitory concentration: > 100000 nM
Compound 4 gave a limit, no number; the forecaster's own chance of this, stated with the estimate: 3%; at least 830-fold (2.92 log units) between middle value and limit.
By their numbers in this assay, from the lowest: compound 1; then compound 2; then compound 3. At a limit, above all of these: compound 4.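

Within the core of compound 1, the group on an oxygen on a saturated carbon proves far from indifferent in this assay: 2,4,5-trichlorophenyl in place of 3-chlorophenyl gives an at least 1600-fold higher number from compound 1 to compound 4 (3.22 log units; beyond the scatter). The result for compound 4 is a limit of the assay and not a number: the limit of > 100000 nM in this assay, at which 1 of the 4 values shown sits. The earlier step, a 7.5-fold higher number from compound 2 to compound 3 (0.88 log units; beyond the scatter), came from a different core and compared two rings with one chlorine each, whereas this step shows a much larger change, and the only difference counted between the two groups lies in their chlorine atoms.

Whether the loss follows from the number of chlorines or from the places they occupy stays open, and the data give no cause for it. A dichlorophenyl group on the core of compound 1 would separate those two readings, while a methoxy group or an amine on the ring would show whether the steep change is tied to chlorine at all.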